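Replacing a 2-nitrophenyl with 3-chlorophenyl on the thioether arm

The source may hold more compounds than are shown below. What is called first, only, known or untested is meant among the compounds shown, and "the series" means these compounds.

Three measured compounds share a core and differ only in the aromatic group on a saturated chain carbon bound to a sulfur: compound 1 `O=[N+]([O-])c1ccccc1CSc1nnc(-c2ccc3c(c2)OCCO3)n1-c1ccccc1`, compound 2 `O=[N+]([O-])c1cccc(CSc2nnc(-c3ccc4c(c3)OCCO4)n2-c2ccccc2)c1` and compound 3 `O=[N+]([O-])c1ccc(CSc2nnc(-c3ccc4c(c3)OCCO4)n2-c2ccccc2)cc1`. In a functional assay on HeLa cells (Homo sapiens) for antiproliferative activity, read by MTT assay, with a stated time of 24 h (on this read-out higher numbers stand for weaker inhibition and lower numbers for stronger inhibition), compound 1 gives 69800 nM, compound 2 gives 45200 nM, and compound 3 gives 36200 nM. Compound 1 stands at the highest of the three numbers, but its neighbours sit close: a 1.5-fold lower number from compound 1 to compound 2 (0.19 log units; within the scatter) and a 1.9-fold lower number from compound 1 to compound 3 (0.29 log units; within the scatter), and a 1.2-fold lower number from compound 2 to compound 3 (0.10 log units; within the scatter) as well, so the three values are not separated beyond the scatter.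

Compound 4 `Clc1cccc(CSc2nnc(-c3ccc4c(c3)OCCO4)n2-c2ccccc2)c1` is not yet measured. It differs from compound 1 in one place: 3-chlorophenyl in place of 2-nitrophenyl on a saturated chain carbon bound to a sulfur. Among the measured compounds shown here, the measured steps that bear on it are those from compound 1 to compound 2 and from compound 1 to compound 3, which move the nitro group around the ring without moving the number beyond the scatter; no measured pair exchanges a nitrophenyl for a chlorophenyl, so that part of the change has no precedent here. Compound 4 is therefore expected to remain near compound 1, with a step of a 1.4-fold lower number from compound 1 to compound 4 (0.14 log units; within the scatter) that is not expected to exceed the scatter. The estimate for compound 4 in this assay is 50000 nM, with a range from 20000 nM to 120000 nM.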

Compound 4, half-maximal inhibitory concentration: 15000 nM
Compound 4: the middle estimate sits 3.3-fold (0.52 log units) above what was measured, and the stated range ends above it.
By their numbers in this assay, from the lowest: compound 4; then compounds 3, 2 and 1 (each within the scatter of the next).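

In this assay, moving the nitro group around the ring had left the numbers within the scatter, but exchanging the group itself on a saturated chain carbon bound to a sulfur gives a change beyond it: a 4.7-fold lower number from compound 1 to compound 4 (0.67 log units; beyond the scatter) and a 2.4-fold lower number from compound 3 to compound 4 (0.38 log units; beyond the scatter). The closest comparison, from 3-nitrophenyl to 3-chlorophenyl, is chloro in place of nitro on an aromatic carbon and gives a 3.0-fold lower number from compound 2 to compound 4 (0.48 log units; beyond the scatter), so this position responds to the identity of the group even when the nitro group's place on the ring does not register, although all three steps are modest. Nothing available here accounts for this difference.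

It remains open whether chloro would respond to its place on the ring any more than nitro did, as would be shown by 2-chlorophenyl and 4-chlorophenyl on the same core, and how an unsubstituted phenyl, a 3-methoxyphenyl or a 3-aminophenyl would compare at this position. The compounds shown also leave open whether the lower number from the 3-chlorophenyl group extends to any cell line other than the one in this assay.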